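Dropping the amino link: compound 4 against compound 1

A few compounds are considered here, and "the series" means these few. Any claim that something is new, unique, unknown or untested is made for them only; others in the source may bear on it.

Three measured compounds share one core, seen in compound 1 `COc1cc(Cl)cc(-c2nn(-c3cccc(NC(=O)Nc4ccc(Cl)c(C(F)(F)F)c4)c3)cc2-c2ccncc2)c1`, compound 2 `COc1cc(Cl)cc(-c2nn(-c3cccc(NC(=O)Nc4cc(C(F)(F)F)cc(C(F)(F)F)c4)c3)cc2-c2ccncc2)c1` and compound 3 `COc1cc(Cl)cc(-c2nn(-c3cccc(NC(=O)Nc4ccc(Cl)c(Cl)c4)c3)cc2-c2ccncc2)c1`. In a functional assay on RPMI-8226 cells (Homo sapiens) for inhibition, read by sulforhodamine B assay, with a stated time of 48 h, tested at 10 uM (on this read-out lower numbers stand for a stronger effect and higher numbers for a weaker effect at the one concentration tested), compound 1 gives -29.1%, the lowest of the three numbers. Compound 2 gives -17.5% and compound 3 gives -4.44%. Within the data shown here, the one single-point step recorded is a number 24.7 percentage points higher from compound 1 to compound 3 (beyond the scatter), and compound 2 stands beyond the scatter above compound 1 as well.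

Compound 4 `COc1cc(Cl)cc(-c2nn(-c3cccc(NC(=O)c4cccc(C(F)(F)F)c4)c3)cc2-c2ccncc2)c1` differs from compound 1 in this way: 3-(trifluoromethyl)phenyl in place of (4-chloro-3-(trifluoromethyl)phenyl)amino on a carbonyl carbon. Among the measured compounds shown here, no measured step touches the carbonyl carbon and its amide-type nitrogen, so the only guide is that every change so far at the distal ring has moved the number upward from compound 1, by the size of a number 24.7 percentage points higher from compound 1 to compound 3 (beyond the scatter) in the one direct case. He therefore expects compound 4 to read higher than compound 1 in this assay, with a step estimated at a number 31.1 percentage points higher from compound 1 to compound 4 (beyond the scatter). Compound 4 is estimated at 2%, within a range from -22% to 26%.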

Compound 4, a percentage reported as activity, at one concentration (the size of the read-out at that concentration, not a potency): 31.5%
Compound 4: middle estimate off by 29.5 percentage points, on the low side; the measured number lies above the stated range.
By their numbers in this assay, from the lowest: compound 1; then compound 2; then compound 3; then compound 4.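

In this assay, putting 3-(trifluoromethyl)phenyl on the carbonyl carbon gives a number 60.6 percentage points higher from compound 1 to compound 4 (beyond the scatter) and a number 35.9 percentage points higher from compound 3 to compound 4 (beyond the scatter), so this place responds strongly when the amino link goes, whichever of the two chlorinated aryl amino groups leaves. Among these compounds, compound 4, at 31.5%, is the only one of the four compounds with a number above zero, while compound 1, compound 2 and compound 3 all stay below it. Nothing measured here accounts for the size of these steps.

As far as these compounds go, each step removes the amino link and also changes the ring substituents, so the part played by each change stays open. Also open, from the compounds shown here alone, is how the number would move with a methylene or an ether oxygen in place of the amino nitrogen on the carbonyl carbon.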